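Swapping an Aromatic Amide Cap for a Saturated Ring

The compounds below may be only part of what the source reports. "The series", "measured", "known", "first", "only" and "open" are said of these compounds alone.

Compound 1 `CCOC(=O)c1sc(-c2cccc(NC(=O)c3ccc(C(F)(F)F)cc3)c2)nc1Nc1ccc(N2CCN(C)CC2)cc1`: 33%
Compound 2 `CN1CCN(c2ccc(Nc3nc(-c4cccc(NC(=O)c5ccc(Cl)cc5)c4)sc3C(=O)O)cc2)CC1`: 90.9%
Compound 3 `CN1CCN(c2ccc(Nc3nc(-c4cccc(NC(=O)c5ccc(C(F)(F)F)cc5)c4)sc3C(N)=O)cc2)CC1`: 91.9%

All three compounds share one core and were tested in a functional assay on Raji cells (Homo sapiens) for antiproliferative activity, read by CCK-8 assay, with a stated time of 72 h, tested at 40 uM; a higher number here means more inhibition at the concentration tested (going by the name of the read-out), a lower number less inhibition. Compound 3 stands at the top of the three numbers, yet compound 2 lies within the usual scatter of it, so the two cannot be ranked against each other. For the measured compounds named here, compound 1 sits far lower: the single change a number 58.9 percentage points higher from compound 1 to compound 3 (beyond the scatter) is the only step between compounds that differ in one place, and it lies on the carbonyl carbon of the ester, not on the amide cap.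

Compound 4 `CN1CCN(c2ccc(Nc3nc(-c4cccc(NC(=O)[C@H]5CC[C@H](C)CC5)c4)sc3C(N)=O)cc2)CC1` differs from compound 3 by 4-methylcyclohexyl in place of 4-(trifluoromethyl)phenyl on a carbonyl carbon. Going by the values given here, no measured step touches this part of the molecule; compounds 2 and 3 differ there, but they also differ at the ester position, so their two values alone show only that a chloro cap and a trifluoromethyl cap both give high numbers. The step from an aromatic cap to a saturated ring is therefore untested here. Compound 3 already has a number near the top of the range of this read-out, so the expected step of a number 19.9 percentage points lower from compound 3 to compound 4 (beyond the scatter) is downward or absent rather than upward. Compound 4 is estimated at 72%, between 35% and 95%.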

Compound 4, a percentage reported as inhibition, at one concentration (the size of the read-out at that concentration, not a potency): 22.4%
Compound 4: the middle estimate sits 49.6 percentage points above what was measured; measured number below the stated range.
By their numbers in this assay, from the lowest: compound 4; then compound 1; then compounds 2 and 3 (each within the scatter of the next).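

In this assay, for the compounds shown here, the amide cap proves to be a sensitive position: replacing 4-(trifluoromethyl)phenyl with 4-methylcyclohexyl on this carbonyl carbon gives a number 69.5 percentage points lower from compound 3 to compound 4 (beyond the scatter) and is the first single change measured at this position. Going by these compounds alone, the only earlier single change, made on a different carbonyl carbon, gave a number 58.9 percentage points higher from compound 1 to compound 3 (beyond the scatter), and the new result shows that the amide kept there in compound 4 does not by itself secure a high number when the cap changes. Nothing available here explains why the number falls so far.

From the compounds shown here alone, the change replaces the aromatic ring with a saturated one and the trifluoromethyl group with a methyl group at the same time, so it remains open which of these matters; an unsubstituted phenyl cap or a 4-(trifluoromethyl)cyclohexyl cap would separate the two. Also open, going by these compounds, is how this position would respond to a cap containing a ring nitrogen, such as piperidine, or to a simple open-chain alkyl group such as tert-butyl.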